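The source may hold more compounds than are shown below. What is called first, only, known or untested is meant among the compounds shown, and "the series" means these compounds.

Compound 1 `CCOC(=O)C1=CCCCC1S(=O)(=O)Nc1ccc(Cl)cc1F` gives 160 nM
Compound 2 `CCOC(=O)C1=CCCCC1S(=O)(=O)Nc1ccc(F)cc1F` gives 16 nM

In a functional assay on RAW264.7 cells (Mus musculus) for inhibition (a higher number here means a weaker inhibitor, a lower number a stronger inhibitor), compound 2 has the lower of these two numbers, which makes it the stronger inhibitor of the pair. Among the measured compounds shown here, the only measured change is a 10-fold lower number from compound 1 to compound 2 (1.00 log units; beyond the scatter) for fluoro in place of chloro on an aromatic carbon. Compound 3 `CC(C)COC(=O)C1=CCCCC1S(=O)(=O)Nc1ccc(F)cc1F` keeps that aromatic part and changes the ester end instead. The difference isopropyl in place of methyl on a saturated chain carbon bound to an oxygen next to a carbonyl group turns ethoxycarbonyl into isobutoxycarbonyl, with isopropyl in place of methyl on a saturated chain carbon bound to an oxygen next to a carbonyl group. For the measured compounds named here, no measured step touches this place, so the fluoro swap is no direct guide, and the direction remains open. Starting from the lower number, a modest rise is the cautious expectation, with wide uncertainty. The expected change is a 1.9-fold higher number from compound 2 to compound 3 (0.27 log units; within the scatter) in this assay for now. For compound 3 the estimate is 30 nM with an expected range from 7 nM to 130 nM as a working guess.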

Compound 3, half-maximal inhibitory concentration: 49 nM
For compound 3 the middle estimate is 1.6-fold (0.21 log units) below the measured one, and the stated range covers the measured number.
By their numbers in this assay, from the lowest: compound 2; then compound 3; then compound 1.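

Among the compounds shown here, until now the only measured step lay in the aromatic part, with a 10-fold lower number from compound 1 to compound 2 (1.00 log units; beyond the scatter) for fluoro in place of chloro. In this assay, the ester end also proves sensitive: ethoxycarbonyl to isobutoxycarbonyl gives a 3.1-fold higher number from compound 2 to compound 3 (0.49 log units; beyond the scatter), so the larger group weakens inhibition, but compound 3 remains an inhibitor at 49 nM. Nothing available explains why this change raises the number.

The compounds shown leave open whether the rise follows the added carbons or the branching, and how a methyl ester, an unbranched butyl chain or a carboxylic acid at this end would behave. They also leave open whether the same ester change would shift the number by a similar amount in compound 1, which carries chloro instead of fluoro.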